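A Methoxy Group Added to a Cytotoxic Series

The source may report more compounds than this note shows. Statements on the series, on what has been measured and on what is new or still open speak of the compounds shown alone.

Measured compounds:
compound 1, `S=C(N/N=C\c1ccnc2ccccc12)Nc1ccc(Br)cc1`, 990 nM
compound 2, `S=C(N/N=C\c1ccnc2ccccc12)Nc1ccccc1`, 1070 nM

Both were tested in a functional assay on MCF7 cells (Homo sapiens) for cytotoxicity, read by MTT assay, with a stated time of 48 h; a higher number here means a weaker inhibitor, a lower number a stronger inhibitor. Compound 2 gives the higher of the two numbers, its nearest neighbour being compound 1, but the step of a 1.1-fold higher number from compound 1 to compound 2 (0.03 log units; within the scatter) is within the scatter, so no real difference between the two compounds can be claimed. Compound 3, `COc1ccc(NC(=S)N/N=C\c2ccnc3ccccc23)cc1`, has not yet been measured. It differs from compound 2 by methoxy in place of hydrogen on an aromatic carbon. Among the measured compounds shown here, no measured pair carries a methoxy group, so no step speaks to this change directly. For the measured compounds named here, the only step available, a 1.1-fold higher number from compound 1 to compound 2 (0.03 log units; within the scatter), shows that replacing bromo with hydrogen on an aromatic carbon produced nothing beyond the scatter, and that is the sole guide here. A change no larger than the scatter is therefore expected, a 1.1-fold lower number from compound 2 to compound 3 (0.03 log units; within the scatter). Compound 3 is estimated at 1000 nM, with a range from 400 nM to 2600 nM.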

Compound 3, half-maximal inhibitory concentration: 990 nM
Compound 3: middle estimate off by 1.0-fold (0.00 log units), on the high side, and the stated range covers the measured number.
By their numbers in this assay, from the lowest: compounds 1, 3 and 2 (each within the scatter of the next).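

In this assay, among the compounds shown here, methoxy in place of hydrogen gives a 1.1-fold lower number from compound 2 to compound 3 (0.03 log units; within the scatter) and so offers the first direct reading of a group with oxygen at this place, on an aromatic carbon para to a large group. Methoxy in place of bromo gives no change at the digits printed from compound 1 to compound 3 (within the scatter) and shows that these two groups cannot be told apart here, so hydrogen, bromo and methoxy at this one place all give numbers within the scatter of one another. Nothing measured here offers a reason for this flat result.

The compounds shown leave open whether a very different group at this place, such as an amine, a carboxylic acid or a longer chain, would move the number beyond the scatter. They also leave open what methoxy would do elsewhere on the shared core.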